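Palmitoyl amides: chain extension on the pyrrolidine amide

The compounds below may be only part of what the source reports. "The series", "measured", "known", "first", "only" and "open" are said of these compounds alone.

Compound 1 `CCCCCCCCCCCCCCCC(=O)N1CCCC1` is a long-chain amide that carries pyrrolidin-1-yl on the carbonyl carbon. Going by the values given here, in a functional assay on U-251 cells (Homo sapiens) for antiproliferative activity, read by sulforhodamine B assay, with a stated time of 48 h (on this read-out lower numbers stand for stronger inhibition of growth and higher numbers for weaker inhibition of growth), compound 1 gives 4.6 ug/mL, the lowest of the two numbers so far. Among the compounds with values here, the only comparison available is compound 2 `CCCCCCCCCCCCCCCC(=O)N1CCOCC1`, in which morpholin-4-yl replaces pyrrolidin-1-yl on the carbonyl carbon; in this assay compound 2 gives 25 ug/mL, and the step of a 5.4-fold higher number from compound 1 to compound 2 (0.74 log units; beyond the scatter) shows that the amine part matters.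

Compound 3 `CCCCCCCCCCCCCCCCCC(=O)N1CCCC1` is not yet measured. It differs from compound 1 only at the far end of the chain: ethyl in place of hydrogen on a saturated chain carbon, ten or more bonds along the chain from a carbonyl carbon. Within the data shown here, no measured step bears on this change; the single step in hand concerns the amine on the carbonyl carbon, not the chain. With the amine kept as pyrrolidin-1-yl, no step beyond the scatter is expected in either direction, and compound 3 is estimated at 5 ug/mL (range 2 ug/mL to 13 ug/mL), which would mean a step of a 1.1-fold higher number from compound 1 to compound 3 (0.04 log units; within the scatter) relative to compound 1.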

Compound 3, concentration for 50% growth inhibition: 8 ug/mL
For compound 3 the middle estimate is 1.6-fold (0.20 log units) below the measured one; the measured number falls inside the stated range.
By their numbers in this assay, from the lowest: compounds 1 and 3 (each within the scatter of the next); then compound 2.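

On the pyrrolidin-1-yl amide, ethyl in place of hydrogen on a saturated chain carbon, ten or more bonds along the chain from a carbonyl carbon, gives a 1.7-fold higher number from compound 1 to compound 3 (0.24 log units; within the scatter), so compound 1 and compound 3 cannot be told apart in this assay. This is the first reading at the chain end, and it contrasts with the amine on the carbonyl carbon, where a 5.4-fold higher number from compound 1 to compound 2 (0.74 log units; beyond the scatter) lies beyond the scatter; among the compounds shown, only the amine exchange gives a step that can be distinguished from assay noise. No supporting data are available to explain either result.

The compounds shown leave open whether a still longer chain, or a shorter one, would give a step beyond the scatter on the pyrrolidin-1-yl amide, and whether a carboxylic acid or an amine at the far end of the chain would be accommodated in the same way as ethyl. They also leave open whether morpholin-4-yl in place of pyrrolidin-1-yl gives a similar step on the chain of compound 3.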